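The source may report more compounds than this note shows. Statements on the series, on what has been measured and on what is new or still open speak of the compounds shown alone.

Working notes on the series in a functional assay on HCT-116 cells (Homo sapiens) for cytotoxicity, read by MTT assay, with a stated time of 72 h; a lower number here means a stronger inhibitor, a higher number a weaker inhibitor.

Three compounds have numbers. Compound 1 `CCOC(=O)C1=C(C)NC(=S)NC1c1cn(C(=O)CNc2ccccc2)c2ccccc12` gives 450 ug/mL. Among the measured compounds shown here, compound 2 `CCOC(=O)C1=C(C)NC(=S)NC1c1cn(C(=O)CNc2ccc([N+](=O)[O-])c(Cl)c2)c2ccccc12` gives 29 ug/mL, and the step between them, a 16-fold lower number from compound 1 to compound 2 (1.19 log units; beyond the scatter), is the only single-place change measured so far. Compound 3 `CCOC(=O)C1=C(C)NC(=O)NC1c1cn(C(=O)CNc2ccc([N+](=O)[O-])cc2Cl)c2ccccc12` gives 5 ug/mL, the lowest of the three numbers; its gap to compound 2 and its gap to compound 1 both lie beyond the scatter. For the measured compounds named here, compound 3 and compound 2 differ in more than one place, so no single step is drawn between them; the two values are simply what they are.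

Compound 4 `CCOC(=O)C1=C(C)NC(=O)NC1c1cn(C(=O)CNc2ccc([N+](=O)[O-])cc2C)c2ccccc12` is the next candidate. Against compound 3 the change is methyl in place of chloro on an aromatic carbon. Going by the values given here, no measured step bears directly on this swap: the one step in hand, from compound 1 to compound 2, replaces a whole phenyl by a 3-chloro-4-nitrophenyl and is large, whereas here one heavy atom is exchanged for one heavy atom with the nitro group kept and no change in donors or acceptors. The expectation is therefore a step in this assay of no more than modest size, if anything toward a slightly higher number, a 1.4-fold higher number from compound 3 to compound 4 (0.15 log units; within the scatter). For compound 4 the estimated value is 7 ug/mL, with a range from 3 ug/mL to 18 ug/mL.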

Compound 4, half-maximal inhibitory concentration: 600 ug/mL
The estimate for compound 4 lay 86-fold (1.93 log units) below the measured number; measured number outside the range, above it.
By their numbers in this assay, from the lowest: compound 3; then compound 2; then compounds 1 and 4 (each within the scatter of the next).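

In this assay, methyl in place of chloro gives a 120-fold higher number from compound 3 to compound 4 (2.08 log units; beyond the scatter) with the rest of the structure unchanged. The position, on an aromatic carbon ortho to a large group and meta to a nitro group, is therefore highly sensitive to this change, even though one heavy atom replaces one heavy atom and the counts of hydrogen-bond donors and acceptors stay the same. Among the compounds shown here, the only earlier step, a 16-fold lower number from compound 1 to compound 2 (1.19 log units; beyond the scatter) in the thiocarbonyl pair, involved replacing phenyl with 3-chloro-4-nitrophenyl, whereas this result shows that a large step does not require a change of that extent. No measurement bearing on the cause of this step is available here.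

The compounds shown leave open whether the low number depends on chloro specifically or would also be seen with fluoro, bromo, methoxy or an amine at this position. They also leave open whether methyl in place of chloro would produce a step of similar size on the thiocarbonyl form of the shared core, or with the nitro group replaced by a nitrile.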